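A Second Fluorine on the Pendant Phenyl Ring

This account rests on a few compounds, and the source may have more. Where it says the series, first, only, none or still open, it means among the compounds named here.

Compound 1 `COc1cc2c(Oc3ccc(NC(=O)c4nn(-c5cccc(F)c5)c(=O)cc4C)cc3F)ccnc2cc1OCCCN1CCCC1` belongs to a set of three close analogues that differ only in the amine at the end of the three-carbon chain. In a functional assay on NCI-H460 cells (Homo sapiens) for inhibition, read by MTT assay, with a stated time of 72 h (a higher number here means a weaker inhibitor, a lower number a stronger inhibitor), compound 1 gives 280 nM, the second highest of the three numbers. Compound 2 `COc1cc2c(Oc3ccc(NC(=O)c4nn(-c5cccc(F)c5)c(=O)cc4C)cc3F)ccnc2cc1OCCCN1CCCCC1` gives 360 nM, and compound 3 `COc1cc2c(Oc3ccc(NC(=O)c4nn(-c5cccc(F)c5)c(=O)cc4C)cc3F)ccnc2cc1OCCCN1CCN(C)CC1` gives 260 nM. The steps among them are all small: a 1.3-fold higher number from compound 1 to compound 2 (0.11 log units; within the scatter), a 1.1-fold lower number from compound 1 to compound 3 (0.03 log units; within the scatter) and a 1.4-fold lower number from compound 2 to compound 3 (0.14 log units; within the scatter). Compound 4 `COc1cc2c(Oc3ccc(NC(=O)c4nn(-c5ccc(F)c(F)c5)c(=O)cc4C)cc3F)ccnc2cc1OCCCN1CCCC1` differs from compound 1 in a different region of the molecule: fluoro in place of hydrogen on an aromatic carbon. Among the compounds with values here, none of the measured steps touches this ring, so they bear on the change only by showing how little the numbers move across the set; a direct precedent for this fluorination is absent. For compound 4 a step of no change at the digits printed from compound 1 to compound 4 (within the scatter) is therefore expected, within the scatter. Compound 4 is estimated at 280 nM, with a range from 120 nM to 650 nM.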

Compound 4, half-maximal inhibitory concentration: 170 nM
Compound 4: the middle estimate sits 1.6-fold (0.22 log units) above what was measured; measured number inside the range.
By their numbers in this assay, from the lowest: compounds 4, 3, 1 and 2 (each within the scatter of the next, the first and the last beyond it).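

In this assay, going from the 3-fluorophenyl group to the 3,4-difluorophenyl group gives a 1.6-fold lower number from compound 1 to compound 4 (0.22 log units; within the scatter). Within the data shown here, this is the first measured change on this ring, as the earlier steps all concerned the amine at the end of the chain, and it shows that a fluoro can enter here, ortho to the existing fluoro group and para to the large group, without the number moving beyond the scatter. Nothing available explains the size or the direction of this step.

The compounds shown leave open whether a chloro or a methoxy group at this position would also stay within the scatter. They also leave open whether the 3,4-difluorophenyl group gives a similar step when the chain ends in piperidin-1-yl or 4-methylpiperazin-1-yl.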